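The source may hold more compounds than are shown below. What is called first, only, known or untested is meant among the compounds shown, and "the series" means these compounds.

Measured so far in a functional assay on the whole organism (strain Wistar albino) for inhibition, with Rattus norvegicus as the target, read by paw edema, with a stated time of 1 h, at a dose of 40 mg/kg by the oral route; on this read-out higher numbers stand for more inhibition at the one dose given (going by the name of the read-out) and lower numbers for less inhibition:
compound 1, `Cc1nc(Cc2ccc(Cl)cc2)sc1C1SCC(=O)N1c1ccc(F)c(Cl)c1`, gives 40.7%;
compound 2, `Cc1ccc(N2C(=O)CSC2c2sc(Cc3ccc(Cl)cc3)nc2C)cc1`, gives 59.9%;
compound 3, `COc1ccc(N2C(=O)CSC2c2sc(Cc3ccc(Cl)cc3)nc2C)cc1`, gives 20.9%.

Compound 3 stands lowest of the three numbers. Its nearest neighbour is compound 1: a number 19.8 percentage points lower from compound 1 to compound 3 (beyond the scatter). Its furthest is compound 2: a number 39 percentage points lower from compound 2 to compound 3 (beyond the scatter). Both steps change only the aryl group on the amide-type nitrogen in the ring.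

Compound 4, `Cc1nc(Cc2ccc(Cl)cc2)sc1C1SCC(=O)N1c1ccccc1`, is not yet measured. It differs from compound 3 by hydrogen in place of methoxy on an aromatic carbon.

Among the measured compounds shown here, the step that bears most directly on this change is the one from compound 2 to compound 3, where methoxy entered on the same aromatic carbon and the number fell by a large amount; the step from compound 1 to compound 3 also shows methoxy at the low end of the series. Taking methoxy away again is therefore expected to move this assay upward, with compound 4 estimated at 42% (range 25% to 60%), an expected step of a number 21.1 percentage points higher from compound 3 to compound 4 (beyond the scatter), most likely landing between compound 3 and compound 2 rather than matching compound 2, since no measured compound carries an unsubstituted phenyl there.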

Compound 4, a percentage reported as inhibition, in the whole organism at one dose (the size of the read-out at that dose, not a potency): "not active" (no number reported)
Nothing numeric was reported for compound 4; no gap can be computed for the estimate.
By their numbers in this assay, from the lowest: compound 3; then compound 1; then compound 2.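

In this assay, among the compounds shown here, compound 4 is reported only as "not active", without a number, so no step from compound 3 to it can be read. The compounds shown leave open how that label compares numerically with compound 3. No available evidence bears on this result.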